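The source may report more compounds than this note shows. Statements on the series, on what has been measured and on what is new or still open speak of the compounds shown alone.

Measured so far in a physicochemical assay for solubility, in phosphate buffer, with a stated time of 18 h; a lower number here means a less soluble compound, a higher number a more soluble compound:
Compound 1 `N#Cc1c(N)nc2nc(C3CCCCC3)ncc2c1N`: 81000 nM
Compound 2 `N#Cc1c(N)nc2nc(Cc3ccccc3)ncc2c1N`: 13000 nM
Compound 3 `Cc1nc(C(C)(C)C)nc2nc(N)c(C#N)c(N)c12`: 37000 nM

Among these three, compound 3 gives 37000 nM, the second highest number. Compound 1 sits higher with 81000 nM, and compound 2 sits lower with 13000 nM.

The next compound to consider is compound 4 `CC(C)(C)c1nc(-c2ccsc2)c2c(N)c(C#N)c(N)nc2n1`, which has thiophen-3-yl in place of methyl on an aromatic carbon.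

Among the compounds with values here, the one measured step that bears on this change is a 6.2-fold lower number from compound 1 to compound 2 (0.79 log units; beyond the scatter), with benzyl in place of cyclohexyl on an aromatic carbon. It points to a lower number for compound 4. It is only a loose guide, however, since it swaps a different pair of groups. Within the data shown here, no measured step starts from methyl or brings in thiophen-3-yl, and the data cannot fix the size of this change. A drop somewhat smaller than the measured one seems the most reasonable expectation in this assay, although a drop of similar size would be no surprise.

The expected change is a 4.1-fold lower number from compound 3 to compound 4 (0.61 log units; beyond the scatter).

For compound 4 the estimated value is 9000 nM, with an expected range from 2500 nM to 30000 nM.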

Compound 4, solubility: 40000 nM
Estimate against measurement, compound 4: 4.4-fold (0.65 log units) below; the whole stated range lies below it.
By their numbers in this assay, from the lowest: compound 2; then compounds 3 and 4 (each within the scatter of the next); then compound 1.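

In this assay, putting thiophen-3-yl in place of methyl on this aromatic carbon, meta to a tert-butyl group, gives a 1.1-fold higher number from compound 3 to compound 4 (0.03 log units; within the scatter) and so leaves compound 3 and compound 4 indistinguishable. A group of 5 heavy atoms containing a five-membered aromatic ring can therefore replace a single carbon here with no measurable difference in this pair, which the earlier step of benzyl in place of cyclohexyl, a 6.2-fold lower number from compound 1 to compound 2 (0.79 log units; beyond the scatter), could not reveal, as it concerned another pair of groups and turns out to be a poor guide to this change. Nothing measured here accounts for the absence of a difference between these two compounds.

From the compounds shown here alone, this is a single swap at one position with a tert-butyl group present, so it remains open whether an amine, a carboxylic acid or a longer alkyl chain at the same carbon would also leave the number within the scatter of compound 3. Going by these compounds, it is equally open whether thiophen-3-yl would give the same outcome if cyclohexyl or benzyl replaced the tert-butyl group.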